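Swapping a Benzyl for an Amide in a Cytotoxicity Test

The compounds below may be only part of what the source reports. "The series", "measured", "known", "first", "only" and "open" are said of these compounds alone.

compound 1 `C[C@@H](NC(=O)[C@H](CCCNC(=N)N)NC(=O)c1ccc(CN(Cc2ccccn2)C(=O)c2ccc(F)cc2)cc1)c1cccc2ccccc12`: 38000 nM
compound 2 `C[C@H](NC(=O)[C@H](CCCNC(=N)N)NC(=O)c1ccc(CN(Cc2ccc(F)cc2)Cc2ccccn2)cc1)c1cccc2ccccc12`: 11000 nM

In an ADME assay on MT4 cells (Homo sapiens) for cytotoxicity (on this read-out higher numbers stand for lower toxicity in this test and lower numbers for higher toxicity in this test), compound 2 gives 11000 nM, the lowest of the two numbers recorded, meaning it is the more toxic of the pair in this test. The nearest number belongs to compound 1, which in this assay gives 38000 nM; the gap between them lies beyond the usual scatter of repeated measurements, so the difference can be taken as real.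

Compound 3 `C[C@H](NC(=O)[C@H](CCCNC(=N)N)NC(=O)c1ccc(CN(Cc2ccccn2)C(=O)c2ccc(F)cc2)cc1)c1cccc2ccccc12` has not yet been measured. It is compound 2 with (4-fluorophenyl)carbonyl in place of 4-fluorobenzyl on an amine nitrogen. Going by the values given here, no measured pair shows exactly this change, so no step size can be read off directly; the data only show that numbers run from the value of compound 2 up to the value of compound 1.

Compound 3 is expected to land in that span, at roughly 25000 nM, with a plausible range from 8000 nM to 70000 nM. The expected step from compound 2 to compound 3 is a 2.3-fold higher number from compound 2 to compound 3 (0.36 log units; beyond the scatter), a modest move toward lower toxicity that may not exceed the scatter.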

Compound 3, half-maximal cytotoxic concentration: 37000 nM
The estimate for compound 3 lay 1.5-fold (0.17 log units) below the measured number; the measured number falls inside the stated range.
By their numbers in this assay, from the lowest: compound 2; then compounds 3 and 1 (each within the scatter of the next).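

In this assay, going by these compounds alone, placing (4-fluorophenyl)carbonyl instead of 4-fluorobenzyl on the amine nitrogen gives a 3.4-fold higher number from compound 2 to compound 3 (0.53 log units; beyond the scatter), the first single-change reading at this position, and it points toward lower toxicity in this test. A second single-change comparison involves two compounds with the same atoms and bonds, which differ only at a stereocentre at a saturated chain carbon, and there the step is a 1.0-fold lower number from compound 1 to compound 3 (0.01 log units; within the scatter), so the earlier gap in this series follows the swap on the nitrogen and not this stereocentre. That reading of the stereocentre carries one caveat: the fact that one of compounds 1 and 3 is drawn with a defined configuration and the other without, at the place where they differ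

The compounds shown leave open whether the higher number depends on the carbonyl alone or on its pairing with the 4-fluorophenyl ring, which a small acetyl group or a sulfonyl link on the same nitrogen would help to separate. Going by these compounds, they also give no measured property that explains the step, and they cover only a single assay, so whether the same swap would behave alike in other cell types remains unknown.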